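Adding a Methyl Group to the Weakest Compound

A few compounds are considered here, and "the series" means these few. Any claim that something is new, unique, unknown or untested is made for them only; others in the source may bear on it.

Among the measured compounds shown here, the compounds measured so far, sharing one core, have been tested in a functional assay on WiDr cells (Homo sapiens) for inhibition, read by sulforhodamine B assay, with a stated time of 48 h; on this read-out lower numbers stand for stronger inhibition of growth and higher numbers for weaker inhibition of growth. Compound 1 `COC(=O)[C@@]1(C)CCC=C2[C@@H]1CC[C@@H](C)[C@]2(C)Cc1c(C)[nH]c2ccc(Br)cc12` gives 15000 nM in this assay, and compound 2 `COC(=O)[C@@]1(C)CCC=C2[C@@H]1CC[C@@H](C)[C@]2(C)Cc1c(C)[nH]c2ccc(Cl)cc12` gives 18000 nM. For the measured compounds named here, the one step that connects two measured compounds, a 1.2-fold higher number from compound 1 to compound 2 (0.08 log units; within the scatter), shows that swapping the two halogens left the read-out essentially unchanged. Compound 3 `COC(=O)[C@@]1(C)CC[C@@H]2C3=C1CC[C@@H](C)[C@]3(C)C[C@@H]1c3ccccc3N[C@H]21`, which carries a differently arranged ring system, gives 50000 nM in this assay, the highest of the measured numbers; it lies beyond the scatter above both compound 1 and compound 2, so of these measured compounds it is the weakest inhibitor of growth.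

Compound 4 `COC(=O)[C@@]1(C)CC[C@@H]2C3=C1CC[C@@H](C)[C@]3(C)C[C@@H]1c3cc(C)ccc3N[C@H]21` is compound 3 with one small change: methyl in place of hydrogen on an aromatic carbon. Going by the values given here, none of the measured steps involves a methyl group or a change at this position, and the single measured step concerns a halogen swap on a different core, so there is no measured step that bears directly on this change. With nothing to point in either direction, the expected step from compound 3 is no change at the digits printed from compound 3 to compound 4 (within the scatter), that is, no change beyond the scatter. For compound 4 the expected value in this assay is therefore 50000 nM, with a range from 20000 nM to 125000 nM.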

Compound 4, concentration for 50% growth inhibition: 32000 nM
Compound 4: middle estimate off by 1.6-fold (0.19 log units), on the high side, and the stated range covers the measured number.
By their numbers in this assay, from the lowest: compounds 1, 2, 4 and 3 (each within the scatter of the next, the first and the last beyond it).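

On the six-membered aromatic ring of carbon only, part of a fused system of five rings, the position that is meta to a fused ring and para to a fused ring now has its first reading. In this assay, methyl in place of hydrogen on an aromatic carbon gives a 1.6-fold lower number from compound 3 to compound 4 (0.19 log units; within the scatter), so this small addition does not separate the two compounds. Among the compounds shown here, until now the only measured step was a swap of halogens on a different core, and this one shows that adding a methyl group here brings neither a clear gain nor a clear loss in growth inhibition. No other measurement bears on this result, and the reason for the number stays unknown.

Going by these compounds, what remains open is whether a different group at this position would move the number beyond the scatter, as an amine, a carboxylic acid or a longer chain on the same aromatic carbon could show. On these data alone, it is also open whether bromo or chloro here, on the core of compound 3, would behave as alike as they do in compound 1 and compound 2.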